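Swapping the aryl group on a weak pair of cell-growth inhibitors

The source may hold more compounds than are shown below. What is called first, only, known or untested is meant among the compounds shown, and "the series" means these compounds.

Compound 2, with the structure `O=C(O)C1=Cc2ccccc2OC1(OCc1cc(-c2cccc(C(F)(F)F)c2)no1)C(F)(F)F`, carries a 3-(trifluoromethyl)phenyl group on its five-membered aromatic ring. Within the data shown here, in a functional assay on DU-145 cells (Homo sapiens) for inhibition, read by MTT assay, with a stated time of 24 h (a lower number here means a stronger inhibitor, a higher number a weaker inhibitor), compound 2 gives 155000 nM, the highest of the two numbers measured so far. Among the measured compounds shown here, its only neighbour is compound 1, `O=C(O)C1=Cc2ccccc2OC1(OCc1cc(-c2ccc([N+](=O)[O-])cc2)no1)C(F)(F)F`, which gives 100000 nM in this assay. The two compounds differ only in the aryl group, and that step, a 1.6-fold higher number from compound 1 to compound 2 (0.19 log units; within the scatter), stays within the scatter, so the two numbers cannot be told apart.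

Compound 3, `Cc1ccc(-c2cc(COC3(C(F)(F)F)Oc4ccccc4C=C3C(=O)O)on2)cc1`, is not yet measured. Its change from compound 2 is 4-methylphenyl in place of 3-(trifluoromethyl)phenyl on an aromatic carbon. For the measured compounds named here, the one measured step that touches the same position, exchanging one aryl group for another, produced no shift beyond the scatter. Going by the values given here, no step involving a methyl group exists, so the expectation rests on that single exchange alone. The estimate for compound 3 in this assay is therefore 130000 nM, with a range from 60000 nM to 300000 nM. This estimate means a step of a 1.2-fold lower number from compound 2 to compound 3 (0.08 log units; within the scatter), which is expected to stay within the scatter.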

Compound 3, half-maximal inhibitory concentration: 41400 nM
The estimate for compound 3 lay 3.1-fold (0.50 log units) above the measured number, and the stated range ends above it.
By their numbers in this assay, from the lowest: compound 3; then compounds 1 and 2 (each within the scatter of the next).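

In this assay, the aryl group on this carbon of the five-membered aromatic ring, next to the ring nitrogen, can change the number after all: 4-methylphenyl gives a 3.7-fold lower number from compound 2 to compound 3 (0.57 log units; beyond the scatter) and a 2.4-fold lower number from compound 1 to compound 3 (0.38 log units; beyond the scatter) and both steps lie beyond the scatter, though both are modest. Among these compounds, the only earlier exchange, a 1.6-fold higher number from compound 1 to compound 2 (0.19 log units; within the scatter) stayed within the scatter, so 4-nitrophenyl and 3-(trifluoromethyl)phenyl could not be told apart, and compound 3 is the first to separate from the others. What lies behind this separation cannot be said, as no other measurement on these compounds bears on it.

The pair of compound 1 and compound 3 keeps the 4-substituted phenyl and changes only nitro to methyl, whereas compound 2 differs from compound 3 in both the group and its place on the phenyl ring, so these compounds cannot show how much each of those two changes contributes. Going by these compounds, it also remains open whether the trend continues with a plain phenyl, a longer chain such as ethyl, or an amine on the phenyl ring, or whether the same methyl would give a similar number at the 3-position.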